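A few compounds are considered here, and "the series" means these few. Any claim that something is new, unique, unknown or untested is made for them only; others in the source may bear on it.

Measured compounds:
- compound 1, `Cc1nc2ccccc2nc1Oc1ccc(C(=O)N[C@@H](C)C(=O)O)cc1`: 22300 nM
- compound 2, `CC[C@@H](C)[C@H](NC(=O)c1ccc(Oc2nc3ccccc3nc2C)cc1)C(=O)O`: 33200 nM
- compound 3, `CCCCCCCCCCCCNc1nc2ccccc2nc1Oc1ccc(C(=O)N[C@@H](C)C(=O)OC)cc1`: 28500 nM

All three were run in a functional assay on HeLa cells (Homo sapiens) for antiproliferative activity, read by MTT assay, with a stated time of 48 h; on this read-out higher numbers stand for weaker inhibition and lower numbers for stronger inhibition. Within the pair sharing the core of compound 1, the change sec-butyl in place of methyl on a saturated chain carbon bound to an amide-type nitrogen and a carbonyl carbon gave a 1.5-fold higher number from compound 1 to compound 2 (0.17 log units; within the scatter). Compound 3 carries a different core; how it differs from the core of compound 1 is not broken down here. In this assay compound 3 sits near compound 2 and near compound 1, all within the scatter of one another.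

Compound 4, `CCCCCCCCCCCCNc1nc2ccccc2nc1Oc1ccc(C(=O)N[C@H](C(=O)OC)[C@H](C)CC)cc1`, is not yet measured. Relative to compound 3 the change is sec-butyl in place of methyl on a saturated chain carbon bound to an amide-type nitrogen and a carbonyl carbon. The place is the same word for word as in the step from compound 1 to compound 2, so this is the same change applied on the core of compound 3.

Among the measured compounds shown here, the only precedent for this change is a 1.5-fold higher number from compound 1 to compound 2 (0.17 log units; within the scatter), a step within the scatter. On that basis the step from compound 3 to compound 4 is expected to be similarly small, a 1.4-fold higher number from compound 3 to compound 4 (0.15 log units; within the scatter), because compound 3 gives 28500 nM as the starting point. Compound 4 is therefore estimated at 40000 nM in this assay, between 20000 nM and 80000 nM.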

Compound 4, half-maximal inhibitory concentration: 40300 nM
Compound 4: middle estimate off by 1.0-fold (0.00 log units), on the low side; the measured number falls inside the stated range.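

In this assay, sec-butyl in place of methyl on a saturated chain carbon bound to an amide-type nitrogen and a carbonyl carbon gives a 1.4-fold higher number from compound 3 to compound 4 (0.15 log units; within the scatter). The two cores shown agree on the size of this step: the same change on two cores in this assay, a 1.5-fold higher number (0.17 log units; within the scatter) from compound 1 to compound 2 and a 1.4-fold higher number (0.15 log units; within the scatter) from compound 3 to compound 4, 1.1-fold (0.02 log units) apart, within the scatter of two such steps

Since each step lies within the scatter, the series offers two pairs in which this change leaves no readable mark on the number, on either core, in this single cell assay. This does not show that a step of real size would carry over from one core to the other, as neither pair contains such a step to follow.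

Still open, on these data alone, is whether a group with a ring, such as benzyl, or a chain bearing an amine at the same place would give a step beyond the scatter on either core. Also open, as far as these compounds go, is whether the methyl-to-sec-butyl step stays this small on a core with a shorter chain on its amino group.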